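Methylating a phenol in two urea and amide analogues

A few compounds are considered here, and "the series" means these few. Any claim that something is new, unique, unknown or untested is made for them only; others in the source may bear on it.

Measured compounds:
- compound 1, `O=C(Nc1cccc(-n2cc(-c3ccncc3)c(-c3cc(O)cc(Cl)c3)n2)c1)Nc1ccc(Cl)c(Cl)c1`: -44.2%
- compound 2, `COc1cc(Cl)cc(-c2nn(-c3cccc(NC(=O)Nc4ccc(Cl)c(Cl)c4)c3)cc2-c2ccncc2)c1`: 15.7%
- compound 3, `O=C(Nc1cccc(-n2cc(-c3ccncc3)c(-c3cc(O)cc(Cl)c3)n2)c1)c1cc(C(F)(F)F)cc(C(F)(F)F)c1`: 58.3%

In a functional assay on HOP-62 cells (Homo sapiens) for inhibition, read by sulforhodamine B assay, with a stated time of 48 h, tested at 10 uM (a higher number here means a weaker effect of the compound at the concentration tested, a lower number a stronger effect), compound 1 gives -44.2%. Compound 2 differs from it by methyl in place of hydrogen on an oxygen on an aromatic ring, and this one change produced a number 59.9 percentage points higher from compound 1 to compound 2 (beyond the scatter). Compound 3 carries a different core; how it differs from compound 1 is not broken down here. In this assay compound 3 gives 58.3%, the highest of the three numbers.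

Compound 4, `COc1cc(Cl)cc(-c2nn(-c3cccc(NC(=O)c4cc(C(F)(F)F)cc(C(F)(F)F)c4)c3)cc2-c2ccncc2)c1`, has not been measured. It stands to compound 3 as compound 2 stands to compound 1: the difference is methyl in place of hydrogen on an oxygen on an aromatic ring, the same change at the same place. For the measured compounds named here, the only guide is the step from compound 1 to compound 2, which was large. Since compound 3 already begins from a weaker point, the same change is expected to move it by a number 29.7 percentage points higher from compound 3 to compound 4 (beyond the scatter), a smaller rise, because the read-out of compound 3, 58.3%, leaves less room before the effect vanishes altogether. Compound 4 is therefore estimated to give 88% in this assay, expected to lie between 60% and 110%.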

Compound 4, a percentage reported as activity, at one concentration (the size of the read-out at that concentration, not a potency): 103%
The estimate for compound 4 lay 15 percentage points below the measured number; measured number inside the range.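

Replacing hydroxy with methoxy on the 3-chloro-5-hydroxyphenyl group weakened the effect on the second core as well in this assay, with a number 44.7 percentage points higher from compound 3 to compound 4 (beyond the scatter). The direction of the change therefore held across the urea and amide analogues, but its size did not stay the same: the same change on two cores in this assay, a number 59.9 percentage points higher (beyond the scatter) from compound 1 to compound 2 and a number 44.7 percentage points higher (beyond the scatter) from compound 3 to compound 4, 15.2 percentage points apart, beyond the scatter of two such steps. These two pairs are too few to establish a general rule, and they neither explain the gap between the steps nor show how the same change would behave on any other core.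

The compounds shown leave open how a longer chain on that oxygen, such as ethyl in place of methyl, would read in this assay. Also open, going by these compounds, is what would happen if an amine or a carboxylic acid took the place of the hydroxy group on either core.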